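This account rests on a few compounds, and the source may have more. Where it says the series, first, only, none or still open, it means among the compounds named here.

In a functional assay on HCT-15 cells (Homo sapiens) for antiproliferative activity, read by sulforhodamine B assay, with a stated time of 48 h, tested at 50 uM (on this read-out lower numbers stand for less inhibition and higher numbers for more inhibition at the one concentration tested (going by the name of the read-out)), compound 1, `CC1=CC[C@H](C(C)C)c2cc(C)c(OC(=O)c3ccc(C)cc3)cc21`, gives 78.9%. Compound 2, `CC1=CC[C@H](C(C)C)c2cc(C)c(OC(=O)c3ccc([N+](=O)[O-])cc3)cc21`, differs from it by nitro in place of methyl on an aromatic carbon and in this assay gives 67.8%, so that the step of a number 11.1 percentage points lower from compound 1 to compound 2 (beyond the scatter). Compound 3, `CC1=CC[C@H](C(C)C)c2cc(C)c(OC(=O)c3cccc(C)c3)cc21`, carries the other core: 3-methylphenyl in place of 4-methylphenyl on a carbonyl carbon. In this assay compound 3 gives 5.3%, the step being a number 73.6 percentage points lower from compound 1 to compound 3 (beyond the scatter), and against compound 2 the step of a number 62.5 percentage points lower from compound 2 to compound 3 (beyond the scatter). Compound 3 therefore gives the lowest number of the three measured compounds in this assay.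

Compound 4, `CC1=CC[C@H](C(C)C)c2cc(C)c(OC(=O)c3cccc([N+](=O)[O-])c3)cc21`, has not yet been measured in this assay. It differs from compound 3 by nitro in place of methyl on an aromatic carbon. This is the same kind of change as that from compound 1 to compound 2, but not the same: there the nitro entered para to a large group, here it enters meta to a large group. In the measured pair that change made a modest downward step. Starting from the low number of compound 3, a further step of that size has little room; the expected step from compound 3 to compound 4 is a number 0.7 percentage points higher from compound 3 to compound 4 (within the scatter), resting on the value of compound 3 in this assay, 5.3%. Compound 4 is accordingly estimated at 6%, between 0% and 25%.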

Compound 4, a percentage reported as inhibition, at one concentration (the size of the read-out at that concentration, not a potency): 45.9%
Estimate against measurement, compound 4: 39.9 percentage points below; the whole stated range lies below it.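

In this assay, nitro in place of methyl on an aromatic carbon does not carry over from one core to the other as a fixed step, and its direction reverses between the two pairs: the same change on two cores in this assay, a number 11.1 percentage points lower (beyond the scatter) from compound 1 to compound 2 and a number 40.6 percentage points higher (beyond the scatter) from compound 3 to compound 4, 51.7 percentage points apart, beyond the scatter of two such steps

On the 3-substituted side the step is a number 40.6 percentage points higher from compound 3 to compound 4 (beyond the scatter), yet the 3-nitrophenyl ester still stays under both 4-substituted esters, with a number 21.9 percentage points lower from compound 2 to compound 4 (beyond the scatter) and a number 33 percentage points lower from compound 1 to compound 4 (beyond the scatter). These two pairs, read at a single concentration in one cell line, show that the outcome of the change depends on the core it is made on, but they do not show why, and they give no rule for any further core.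

The compounds shown leave open whether an amine, a carboxylic acid or a methoxy group on the same phenyl ring would follow the methyl esters or the nitro esters. Also open, on these data alone, is whether an amide in place of the ester would keep these differences.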